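The compounds below may be only part of what the source reports. "The series", "measured", "known", "first", "only" and "open" are said of these compounds alone.

Compound 1 `CC(C)(C)N(NC(=O)c1ccccc1Cl)C(=O)c1ccccc1Cl` gives the highest number of the two measured in an assay on cells for agonist activity at ecdysone receptor (Bombyx mori), read by a luciferase reporter, with a stated time of 24 h (on this read-out lower numbers stand for an effect already at smaller amounts and higher numbers for an effect only at larger amounts of compound), at 331 nM. Compound 2 `CC(C)(C)N(NC(=O)c1cccc(Cl)c1)C(=O)c1ccccc1Cl` gives 155 nM in this assay; the step of a 2.1-fold lower number from compound 1 to compound 2 (0.33 log units; beyond the scatter) is the only one in hand. Compound 3 `Cc1ccc(C(=O)NN(C(=O)c2ccccc2Cl)C(C)(C)C)cc1` is unmeasured. Relative to compound 1 it carries 4-methylphenyl in place of 2-chlorophenyl on a carbonyl carbon. The measured step bears on this only loosely, since both changes exchange the 2-chlorophenyl on the same carbonyl carbon for another aromatic group, and that step was modest. A step of similar size toward a lower number is expected, a 2.2-fold lower number from compound 1 to compound 3 (0.34 log units; beyond the scatter). Compound 3 is estimated at 150 nM, with a range from 50 nM to 500 nM.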

Compound 3, half-maximal effective concentration: 18.6 nM
Compound 3: middle estimate off by 8.1-fold (0.91 log units), on the high side; the whole stated range lies above it.
By their numbers in this assay, from the lowest: compound 3; then compound 2; then compound 1.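

On this carbonyl carbon, the choice of aromatic group moves the number in this assay much further than the step between the two chlorophenyl compounds showed: 4-methylphenyl gives an 18-fold lower number from compound 1 to compound 3 (1.25 log units; beyond the scatter) and an 8.3-fold lower number from compound 2 to compound 3 (0.92 log units; beyond the scatter). Heavy-atom count stays the same across the change, so that count does not track the shift. No evidence in hand accounts for the shift.

The compounds shown do not separate the loss of chlorine from the gain of methyl. Also open, from the compounds shown here alone, is how a plain phenyl, a longer chain or an amine in place of that methyl would read.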